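Dropping a Chloro Group: Expected Cytotoxicity of Compound 4

The compounds below may be only part of what the source reports. "The series", "measured", "known", "first", "only" and "open" are said of these compounds alone.

Measured compounds in an ADME assay on HEK293 cells (Homo sapiens) for cytotoxicity, read by reporter gene assay and resazurin assay, with a stated time of 48 h; a higher number here means that more compound is tolerated, a lower number that less compound is tolerated:
- compound 1, `O=C(Nc1ccc(Sc2nc3ccccc3s2)cc1)c1cc(Br)cc(Br)c1O`, gives 66000 nM
- compound 2, `COc1ccc(Br)cc1C(=O)Nc1ccc(Sc2nc3ccccc3s2)cc1`, gives > 100000 nM
- compound 3, `O=C(Nc1ccc(Sc2nc3ccccc3s2)c(Cl)c1)c1cccc(Br)c1`, gives > 100000 nM, which is a limit of the assay and not a number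

Compound 3 therefore stands at the limit of > 100000 nM in this assay, at which 2 of the 3 values shown sit, and no number is known for it. Compound 4, `O=C(Nc1ccc(Sc2nc3ccccc3s2)cc1)c1cccc(Br)c1`, has not yet been measured. It differs from compound 3 by hydrogen in place of chloro on an aromatic carbon. Among the compounds with values here, the one measured step, an at least 1.5-fold higher number from compound 1 to compound 2 (0.18 log units; that floor lies within the scatter), concerns a different part of the molecule and does not bear on this change. No measured step covers the loss of a chloro group, so the data give no reason to expect a step beyond the scatter in either direction. Compound 3 already sits at the limit, and compound 4 is expected to do the same or to give a number close to it. Compound 4 is estimated at 150000 nM, within 60000 nM to 350000 nM, which means an expected step that the limit leaves unreadable from compound 3 to compound 4.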

Compound 4, half-maximal cytotoxic concentration: 74000 nM
Compound 4: the middle estimate sits 2.0-fold (0.31 log units) above what was measured; low and high end bracket the measured number.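

With hydrogen in place of chloro, this assay returns a number instead of a limit, and the change amounts to an at least 1.3-fold lower number from compound 3 to compound 4 (0.13 log units; that floor lies within the scatter). Hydrogen in place of methoxy gives an at least 1.3-fold lower number from compound 2 to compound 4 (0.13 log units; that floor lies within the scatter), and 3-bromophenyl in place of 3,5-dibromo-2-hydroxyphenyl gives a 1.1-fold higher number from compound 1 to compound 4 (0.05 log units; within the scatter), so none of these steps is shown to go beyond the scatter. The true size of the chloro step stays unknown because compound 3 is held at a limit of the assay: the limit of > 100000 nM in this assay, at which 2 of the 4 values shown sit.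

As far as these compounds go, what fluoro, methyl or an amine on this aromatic carbon would give remains open. So does the effect of the chloro group when 5-bromo-2-methoxyphenyl or 3,5-dibromo-2-hydroxyphenyl sits on the carbonyl carbon.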